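The source may hold more compounds than are shown below. What is called first, only, known or untested is meant among the compounds shown, and "the series" means these compounds.

Compound 1, `COc1ccc(/C=C\c2cc(OC)c(OC)c(OC)c2)cc1OCc1ccc(CN2CC[C@H](C(=O)O)C2)cc1`, carries the carboxy group on the pyrrolidine ring drawn in the S configuration. In a functional assay on B16-F10 cells (Mus musculus) for antiproliferative activity, read by CCK-8 assay, with a stated time of 48 h (a lower number here means a stronger inhibitor, a higher number a weaker inhibitor), compound 1 gives 7000 nM. Compound 2, `COc1ccc(/C=C\c2cc(OC)c(OC)c(OC)c2)cc1OCc1ccc(CN2CC[C@H](O)C2)cc1`, is the matched pair in which the change hydroxy in place of carboxy on a saturated ring carbon has been made. For compound 2 only a limit is reported in this assay, namely > 10000 nM. The step of an at least 1.4-fold higher number from compound 1 to compound 2 (0.15 log units; that floor lies within the scatter) is therefore read as a floor, because the limit of > 10000 nM in this assay, at which 2 of the 3 values shown sit, sets the bound on one side.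

Compound 3, `COc1ccc(/C=C\c2cc(OC)c(OC)c(OC)c2)cc1OCc1ccc(CN2CC[C@@H](C(=O)O)C2)cc1`, shares the core of compound 1 and differs only as the two compounds have the same atoms and bonds and differ only in configuration as drawn: 1 of 2 stereo elements differ; a stereocentre at a saturated ring carbon is drawn S in compound 1 and R in compound 3. For compound 3 too only a limit is available in this assay, > 10000 nM. The step of an at least 1.4-fold higher number from compound 1 to compound 3 (0.15 log units; that floor lies within the scatter) is again a floor, and the pair 2 to 3 gives a step that the two limits leave unreadable from compound 2 to compound 3.

Compound 4, `COc1ccc(/C=C\c2cc(OC)c(OC)c(OC)c2)cc1OCc1ccc(CN2CC[C@@H](O)C2)cc1`, has not been measured. It stands to compound 3 as compound 2 stands to compound 1, the change (hydroxy in place of carboxy on a saturated ring carbon), at the same place in both pairs. Starting from a compound whose value is itself a limit, compound 4 is expected to move by a step that the limit leaves unreadable from compound 3 to compound 4, resting on the floor seen from compound 1 to compound 2. The estimated value for compound 4 in this assay is 15000 nM, within 8000 nM to 40000 nM.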

Compound 4, half-maximal inhibitory concentration: > 10000 nM
Compound 4 gave a limit, no number; the forecaster's own chance of this, stated with the estimate: 80%; the middle value lies beyond the limit too.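

In this assay compound 4 gives > 10000 nM, which is a limit of the assay and not a number. The change from carboxy to hydroxy on the core of compound 3 cannot be sized, and neither can the comparison of the two hydroxy compounds, because each of these steps has a limit at both ends: the limit of > 10000 nM in this assay, at which 3 of the 4 values shown sit.

For the compounds shown here, the one readable new step is an at least 1.4-fold higher number from compound 1 to compound 4 (0.15 log units; that floor lies within the scatter), and it is only a floor, so the result fits the change carrying over from the core of compound 1 to the core of compound 3 without showing that it has the same size on both.

The compounds shown leave open how far compound 2, compound 3 and compound 4 lie from one another, and whether the configuration at the ring carbon matters for the hydroxy compounds. Also open, going by these compounds, is how an amine or a methyl ester on the same saturated ring carbon would read in this assay.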